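Swapping the aryl group on a sulfonamide nitrogen

The source may hold more compounds than are shown below. What is called first, only, known or untested is meant among the compounds shown, and "the series" means these compounds.

Going by the values given here, compound 2 `COc1cc(NS(=O)(=O)c2ccc(-c3cnc(C4CC4)o3)cc2)ccc1F` is the only compound in this small set with a plain number in a functional assay on cells (leukaemia cell line, Homo sapiens) for inhibition, read by sulforhodamine B assay, with a stated time of 48 h; on this read-out lower numbers stand for stronger inhibition of growth and higher numbers for weaker inhibition of growth. In this assay compound 2 gives 75700 nM. Compound 1 `O=S(=O)(Nc1cc(Cl)ccc1Cl)c1ccc(-c2cnc(C3CC3)o2)cc1` carries a 2,5-dichlorophenyl on the same sulfonamide nitrogen. In this assay compound 1 returns > 100000 nM, which is a limit of the assay rather than a measured number (the limit of > 100000 nM in this assay, at which 1 of the 2 values shown sits). Among the compounds with values here, the one comparable step, an at least 1.3-fold lower number from compound 1 to compound 2 (0.12 log units; that floor lies within the scatter), therefore sets only a floor and lies within the scatter, so it offers no firm direction.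

Compound 3 `Cc1ccc(Cl)c(NS(=O)(=O)c2ccc(-c3cnc(C4CC4)o3)cc2)c1` is not yet measured. It differs from compound 2 as follows: 2-chloro-5-methylphenyl in place of 4-fluoro-3-methoxyphenyl on a sulfonamide nitrogen. The entering group brings back a chlorine on the phenyl, as in compound 1, whose result in this assay was only a limit, > 100000 nM. Within the data shown here, with one within-scatter step as the sole guide, no step beyond the scatter is expected, though a limit result is quite possible. Compound 3 is estimated at 100000 nM, with a range from 40000 nM to 250000 nM. That estimate is expected to mean a 1.3-fold higher number from compound 2 to compound 3 (0.12 log units; within the scatter).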

Compound 3, concentration for total growth inhibition: 52800 nM
The estimate for compound 3 lay 1.9-fold (0.28 log units) above the measured number, within the range that was stated.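

At this sulfonamide nitrogen, compound 3 gives a second plain number in this assay, so two aryl groups can now be compared directly and not only against a limit (a 1.4-fold lower number from compound 2 to compound 3 (0.16 log units; within the scatter)), and that step shows no real difference between 2-chloro-5-methylphenyl and 4-fluoro-3-methoxyphenyl. Compounds 1 and 3 also differ in one place, methyl in place of chloro on an aromatic carbon, and this adds a smaller change on the same phenyl (an at least 1.8-fold lower number from compound 1 to compound 3 (0.27 log units; that floor lies within the scatter)). That second step gives only a floor, with no firm direction, because compound 1 stands at a limit: (the limit of > 100000 nM in this assay, at which 1 of the 3 values shown sits).

All three compounds carry a substituted phenyl on the sulfonamide nitrogen, so the set leaves open whether any change at this position can move the number beyond the scatter. On these data alone, the effect of an amine or a carboxylic acid on that phenyl, or of a pyridine in its place, remains unknown, as does the effect of any change to the shared core.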